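Phenyl amide change from compound 2 to compound 3

This account rests on a few compounds, and the source may have more. Where it says the series, first, only, none or still open, it means among the compounds named here.

compound 1 `CN1CCC(C(=O)N2Cc3c(NC(=O)C4CC4)n[nH]c3C2(C)C)CC1` gives 1420 nM
compound 2 `CN1CCC(C(=O)N2Cc3c(NC(=O)c4ccc(Cl)cc4)n[nH]c3C2(C)C)CC1` gives 120 nM
compound 3 `CN1CCC(C(=O)N2Cc3c(NC(=O)c4ccc(F)c(F)c4)n[nH]c3C2(C)C)CC1` is not yet measured

In a functional assay on A2780 cells (Homo sapiens) for antiproliferative activity, read by fluorescence, with a stated time of 72 h (on this read-out higher numbers stand for weaker inhibition and lower numbers for stronger inhibition), compound 2 holds the lower of the two numbers, with 120 nM as its value. The next change is 3,4-difluorophenyl in place of 4-chlorophenyl on a carbonyl carbon in compound 3. Within the data shown here, the only measured step is a 12-fold lower number from compound 1 to compound 2 (1.07 log units; beyond the scatter) on replacing cyclopropyl with 4-chlorophenyl, and no measured step compares two phenyl groups. No step beyond the scatter is therefore expected in this assay for this change, and the expected step is a 1.3-fold higher number from compound 2 to compound 3 (0.10 log units; within the scatter) with no firm direction. Compound 3 is estimated at 150 nM with an expected range from 60 nM to 370 nM in this read-out.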

Compound 3, half-maximal inhibitory concentration: 100 nM
Beside the measured number, compound 3's estimate is 1.5-fold (0.18 log units) above it; measured number inside the range.
By their numbers in this assay, from the lowest: compounds 3 and 2 (each within the scatter of the next); then compound 1.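

In this assay, 3,4-difluorophenyl in place of 4-chlorophenyl on the carbonyl carbon gives a 1.2-fold lower number from compound 2 to compound 3 (0.08 log units; within the scatter) and so leaves the two phenyl groups indistinguishable at this position. The difference from cyclopropyl remains with a 14-fold lower number from compound 1 to compound 3 (1.15 log units; beyond the scatter) and is thus not confined to the 4-chlorophenyl group. No available evidence bears on why the two phenyl groups read alike.

Still open, on these data alone, is whether unsubstituted phenyl, or phenyl carrying an amine or a carboxylic acid, would stay at this level. Also open, as far as these compounds go, is how a pyridine ring or a longer alkyl chain on the same carbonyl carbon would read.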